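From 4-chlorobenzyl to 3-bromobenzyl on a shared core

This account rests on a few compounds, and the source may have more. Where it says the series, first, only, none or still open, it means among the compounds named here.

Of the compounds shown here, two with one shared core have been tested so far in a functional assay on HepG2 cells (Homo sapiens) for antiproliferative activity, read by MTT assay, with a stated time of 24 h; on this read-out higher numbers stand for weaker inhibition and lower numbers for stronger inhibition. Compound 1 `COc1cccc(C(=O)Oc2ccc3c(=O)c(-c4cc(OC)c(OC)cc4OC)coc3c2)c1` gives only a limit of the assay, > 10000 nM. Among the measured compounds shown here, compound 2 `COc1cc(OC)c(-c2coc3cc(OCc4ccc(Cl)cc4)ccc3c2=O)cc1OC` gives 940 nM, the only actual number available so far.

Compound 3 `COc1cc(OC)c(-c2coc3cc(OCc4cccc(Br)c4)ccc3c2=O)cc1OC` differs from compound 2 in one place: 3-bromophenyl in place of 4-chlorophenyl on a saturated chain carbon bound to an oxygen on an aromatic ring. In words, 3-bromophenyl stands in place of 4-chlorophenyl on a saturated chain carbon bound to an oxygen on an aromatic ring, so 4-chlorobenzyl becomes 3-bromobenzyl.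

For the measured compounds named here, the only measured step that bears on this, an at least 10-fold lower number from compound 1 to compound 2 (1.02 log units; beyond the scatter), is large and beyond the scatter. It shows that the group on this oxygen can matter in this pair, but it replaced (3-methoxyphenyl)carbonyl with 4-chlorobenzyl, a different kind of change. Going by the values given here, no measured step tests a swap between these two benzyl groups. A step beyond the scatter is therefore not expected, and the estimated change is small: a 1.1-fold higher number from compound 2 to compound 3 (0.03 log units; within the scatter). For compound 3 the estimate is 1000 nM, with an expected range from 300 nM to 3500 nM.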

Compound 3, half-maximal inhibitory concentration: 870 nM
Beside the measured number, compound 3's estimate is 1.1-fold (0.06 log units) above it, and the stated range covers the measured number.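

In this assay, among the compounds shown here, this is the first comparison of two benzyl groups on this oxygen, and it gives a 1.1-fold lower number from compound 2 to compound 3 (0.03 log units; within the scatter), so the assay does not tell 4-chlorobenzyl and 3-bromobenzyl apart, even though both the halogen and its place on the ring differ. Set against the (3-methoxyphenyl)carbonyl group of compound 1, the new benzyl group gives an at least 11-fold lower number from compound 1 to compound 3 (1.06 log units; beyond the scatter), so the large step is now seen with two different halogen-bearing benzyl groups rather than with 4-chlorobenzyl alone. The value of compound 1 is a limit and not a number, so this step gives only a minimum size: the limit of > 10000 nM in this assay, at which 1 of the 3 values shown sits.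

On these data alone, because the halogen and its place changed together, the effect of each alone remains open, and 3-chlorobenzyl or 4-bromobenzyl would be needed to separate them. As far as these compounds go, it is also open whether a halogen is needed at all, and how a plain benzyl group, a longer chain such as 2-phenylethyl, or a chain ending in an amine would read on this oxygen.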